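The compounds below may be only part of what the source reports. "The series", "measured", "known", "first", "only" and "open" are said of these compounds alone.

For the measured compounds named here, in a functional assay on ACHN cells (Homo sapiens) (on this read-out lower numbers stand for stronger inhibition of growth and higher numbers for weaker inhibition of growth), compound 3 `O=S(=O)(/C=C/c1ccc(Cl)c(Cl)c1)Cc1ccc(Nc2ncnc3ccccc23)cc1` gives 28000 nM, the second highest of the three numbers measured so far. Compound 1 `O=S(=O)(/C=C/c1ccccc1)Cc1ccc(Nc2ncnc3ccccc23)cc1` stands higher at 58000 nM, while compound 2 `O=S(=O)(/C=C/c1ccc(F)cc1)Cc1ccc(Nc2ncnc3ccccc23)cc1` stands far lower at 10 nM. Compound 4 `O=S(=O)(/C=C/c1ccc(Br)cc1)Cc1ccc(Nc2ncnc3ccccc23)cc1` is still unmeasured, and it differs from compound 3 in one place: 4-bromophenyl in place of 3,4-dichlorophenyl on a double-bonded chain carbon bound to a double-bonded chain carbon.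

Going by the values given here, three measured steps bear on this change. Putting 3,4-dichlorophenyl in place of phenyl gave only a 2.1-fold lower number from compound 1 to compound 3 (0.32 log units; beyond the scatter). Putting fluoro in place of hydrogen gave a 5800-fold lower number from compound 1 to compound 2 (3.76 log units; beyond the scatter), and going from 4-fluorophenyl to 3,4-dichlorophenyl gave a 2800-fold higher number from compound 2 to compound 3 (3.45 log units; beyond the scatter). The 4-bromophenyl of compound 4 is closest in name to the 4-fluorophenyl of compound 2, which has 10 nM. Among the compounds with values here, no bromo compound has been measured, however, and a single compound cannot show how far that likeness carries.

In this assay, a sizeable move towards stronger inhibition is therefore expected, estimated as a 19-fold lower number from compound 3 to compound 4 (1.27 log units; beyond the scatter). The expected value for compound 4 is 1500 nM, with an estimated range from 20 nM to 50000 nM.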

Compound 4, concentration for 50% growth inhibition: 200 nM
Compound 4: the middle estimate sits 7.5-fold (0.88 log units) above what was measured; the measured number falls inside the stated range.
By their numbers in this assay, from the lowest: compound 2; then compound 4; then compound 3; then compound 1.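

In this assay, the large drop seen with fluoro turns out not to be unique to that group: bromo in place of hydrogen on the aromatic carbon also gives a 290-fold lower number from compound 1 to compound 4 (2.46 log units; beyond the scatter). The halogen's identity and the ring's pattern of groups still matter, as bromo in place of fluoro gives a 20-fold higher number from compound 2 to compound 4 (1.30 log units; beyond the scatter), while 4-bromophenyl in place of 3,4-dichlorophenyl gives a 140-fold lower number from compound 3 to compound 4 (2.15 log units; beyond the scatter). No measurement here explains why these groups differ so widely.

The compounds shown leave open where 4-chlorophenyl would fall, which would help separate the effect of the kind of halogen from that of having a second one on the ring. They also leave open whether a group without a halogen, such as methoxy or an amine, could lower the number in the same way.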